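The source may report more compounds than this note shows. Statements on the series, on what has been measured and on what is new or still open speak of the compounds shown alone.

Compound 1 `CNC(=O)c1oc2nc(-c3ccccc3)cc(C(F)(F)F)c2c1N`: 62000 nM
Compound 2 `Nc1c(C(=O)N/N=C/c2ccccc2)oc2nc(-c3cccs3)cc(C(F)(F)F)c12`: 72000 nM
Compound 3 `CNC(=O)c1oc2nc(-c3cccs3)cc(C(F)(F)F)c2c1N`: 75000 nM

In an ADME assay on HEK293 cells (Homo sapiens) for antiproliferative activity, read by MTT assay (a lower number here means a stronger inhibitor, a higher number a weaker inhibitor), compound 1 gives 62000 nM, and the two other measured numbers lie within the usual scatter of it: compound 2 gives 72000 nM and compound 3 gives 75000 nM. Compound 4 `Nc1c(C(=O)N/N=C/c2ccc(Br)cc2)oc2nc(-c3ccccc3)cc(C(F)(F)F)c12` arises from compound 1 by a group of 9 heavy atoms (7 carbon, 1 nitrogen, 1 bromine; one six-membered aromatic ring of carbon only) in place of one carbon atom, on an amide-type nitrogen. The closest guide is the reverse of a similar change on a related core, which stayed within the scatter: a 1.0-fold higher number from compound 2 to compound 3 (0.02 log units; within the scatter). Exchanging phenyl for thiophen-2-yl on an aromatic carbon likewise moved nothing: a 1.2-fold higher number from compound 1 to compound 3 (0.08 log units; within the scatter). A step beyond the scatter is therefore not expected in this assay, in either direction. Compound 4 is expected to give 65000 nM, within 30000 nM to 140000 nM, so the estimated step is a 1.0-fold higher number from compound 1 to compound 4 (0.02 log units; within the scatter).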

Compound 4, half-maximal inhibitory concentration: 64000 nM
Estimate against measurement, compound 4: 1.0-fold (0.01 log units) above, within the range that was stated.
By their numbers in this assay, from the lowest: compounds 1, 4, 2 and 3 (each within the scatter of the next).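

In this assay, putting a group of 9 heavy atoms, including a bromine and a six-membered aromatic ring, in place of the methyl on the amide-type nitrogen gives a 1.0-fold higher number from compound 1 to compound 4 (0.01 log units; within the scatter). For the compounds shown here, a similar exchange had so far been seen only with thiophen-2-yl on the core and without bromine; here it stays within the scatter with phenyl on the core and bromine in the entering group. No measurement shown explains this flat result. Still open, going by these compounds, is whether a carboxylic acid or an amine in place of that bromine would give a step beyond the scatter.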